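Swapping the Amide Aryl Group on an Inactive Scaffold

The compounds below may be only part of what the source reports. "The series", "measured", "known", "first", "only" and "open" are said of these compounds alone.

Compound 1 `COc1ccc2c(=O)c(/C=C/C(=O)Nc3cc(C)ccc3C)coc2c1` — > 200000 nM
Compound 2 `O=C(/C=C/c1coc2cc(O)ccc2c1=O)NCc1ccccc1` — > 200000 nM

In a functional assay on L02 cells (Homo sapiens) for inhibition, read by MTT assay, with a stated time of 48 h (on this read-out lower numbers stand for stronger inhibition and higher numbers for weaker inhibition), compound 1 gives > 200000 nM, which is a limit of the assay rather than a measured number. Compound 2 likewise gives > 200000 nM in this assay, again a limit. Both values shown therefore sit at the limit of > 200000 nM in this assay, at which 2 of the 2 values shown sit, so compound 1 stands no differently from compound 2 on the numbers available.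

Compound 3 `COc1ccc2c(=O)c(/C=C/C(=O)Nc3ccccc3OC)coc2c1` has not yet been measured in this assay. It differs from compound 1 in one place: 2-methoxyphenyl in place of 2,5-dimethylphenyl on an amide-type nitrogen. Within the data shown here, no step between measured compounds exists to gauge a change of this kind. Because compound 1 gives only > 200000 nM, the step of a number no higher from compound 1 to compound 3 (the limit leaves the size open) is expected to be none beyond the scatter. Compound 3 is accordingly estimated at 200000 nM in this assay, within a range from 100000 nM to 400000 nM, and is most likely to be reported again only as a limit.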

Compound 3, half-maximal inhibitory concentration: > 200000 nM
Compound 3: only a limit was reported (the forecaster's own chance of this, stated with the estimate: 85%); the middle value lies on the limit itself.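

Compound 1 and compound 3 are both reported only as limits in this assay, so no step can be read for 2-methoxyphenyl in place of 2,5-dimethylphenyl. The compounds shown leave open whether either amide group affects inhibition at all, because every value rests at one bound: the limit of > 200000 nM in this assay, at which 3 of the 3 values shown sit.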